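Trimming the oxetane: from compound 1 to compound 3

A few compounds are considered here, and "the series" means these few. Any claim that something is new, unique, unknown or untested is made for them only; others in the source may bear on it.

Among the compounds with values here, compound 1 `CC1(C)C[C@@H](CN([C@H](CCC(F)(F)F)C(N)=O)S(=O)(=O)c2ccc(Cl)cc2)O1` gives 16.5 mL/min/kg in an in vitro ADME assay on microsomes from liver (Homo sapiens) for metabolic stability, read by HPLC (a higher number here means faster removal of the compound, a lower number slower removal), the lowest of the two numbers measured so far. Compound 2 `NC(=O)[C@@H](CCC(F)(F)F)N(CC1CCCC1)S(=O)(=O)c1ccc(Cl)cc1` gives 229 mL/min/kg in this assay; the step of a 14-fold higher number from compound 1 to compound 2 (1.14 log units; beyond the scatter) came from putting cyclopentyl in place of the whole 4,4-dimethyloxetan-2-yl ring. Compound 3 `NC(=O)[C@@H](CCC(F)(F)F)N(C[C@H]1CCO1)S(=O)(=O)c1ccc(Cl)cc1` differs from compound 1 by oxetan-2-yl in place of 4,4-dimethyloxetan-2-yl on a saturated chain carbon bound to a sulfonamide nitrogen. Within the data shown here, no measured step tests this smaller change, since the only known step exchanged the ring rather than trimming it, so it gives little direct guidance. Compound 3 is therefore expected to stay close to compound 1, with a step of a 1.2-fold lower number from compound 1 to compound 3 (0.07 log units; within the scatter) within the scatter. The estimate for compound 3 is 14 mL/min/kg, between 7 mL/min/kg and 30 mL/min/kg.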

Compound 3, clearance: 63.8 mL/min/kg
Beside the measured number, compound 3's estimate is 4.6-fold (0.66 log units) below it, and the stated range ends below it.
By their numbers in this assay, from the lowest: compound 1; then compound 3; then compound 2.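

In this assay, trimming 4,4-dimethyloxetan-2-yl to oxetan-2-yl keeps the four-membered ring yet gives a 3.9-fold higher number from compound 1 to compound 3 (0.59 log units; beyond the scatter), so the number at this position depends on more than the presence of the ring. Oxetan-2-yl also stays well short of cyclopentyl, with a 3.6-fold lower number from compound 2 to compound 3 (0.56 log units; beyond the scatter), which places compound 3 in the middle of the series. No measurement shown here explains either step.

Still open, on these data alone, is how an amine or a longer ether chain would fare on this saturated chain carbon bound to a sulfonamide nitrogen.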